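The compounds below may be only part of what the source reports. "The series", "measured", "known", "first", "only" and "open" are said of these compounds alone.

Measured so far in an ADME assay on Vero cells (Chlorocebus sabaeus) for cytotoxicity, read by MTT assay, with a stated time of 72 h; a lower number here means a stronger inhibitor, a higher number a weaker inhibitor
compound 1 `Cc1ccc(C)n1-c1ccc(C(=O)N/N=C/c2ccc(N(C)C)cc2)cc1` gives "not determined" (no result reported)
compound 2 `CC(=O)N1N=C(c2ccc(-n3c(C)ccc3C)cc2)OC1c1cccc([N+](=O)[O-])c1` gives 188000 nM

Among the measured compounds shown here, compound 2 holds the only number so far, so nothing can yet be ranked against it. Next comes compound 3 `CC(=O)N1N=C(c2ccc(-n3c(C)ccc3C)cc2)OC1c1ccccc1` with hydrogen in place of nitro on an aromatic carbon as its difference from compound 2, hydrogen in place of nitro on an aromatic carbon, which reads as 3-nitrophenyl to phenyl. For the measured compounds named here, no measured pair shows this change or any other, so no measured step can guide the expectation. Going by the values given here, the sole anchor is compound 2 at 188000 nM in this assay and no step beyond the usual scatter is expected, in either direction. The estimated change is a 1.1-fold higher number from compound 2 to compound 3 (0.03 log units; within the scatter) and it is expected to stay small. For compound 3 the estimated value is 200000 nM with an expected range from 90000 nM to 450000 nM in this read-out.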

Compound 3, half-maximal inhibitory concentration: 190000 nM
The estimate for compound 3 lay 1.1-fold (0.02 log units) above the measured number; low and high end bracket the measured number.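

In this assay, among the compounds shown here, hydrogen in place of nitro on an aromatic carbon gives a 1.0-fold higher number from compound 2 to compound 3 (0.00 log units; within the scatter), the first step that can be read at all. At this place on the six-membered aromatic ring, 3-nitrophenyl and phenyl therefore read alike, so the reading of compound 2 does not depend on its nitro group, at least within this one pair. No measurement at hand bears on why the two compounds read alike.

Still open, as far as these compounds go, is whether another group at this place, such as an amine, a carboxylic acid or a methoxy group, would also read alike. For the compounds shown here, compound 1 offers no number for comparison, so the pair of compound 2 and compound 3 remains the only guide to how far this reading holds across the series.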